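The compounds below may be only part of what the source reports. "The series", "measured", "known", "first", "only" and "open" are said of these compounds alone.

Measured so far in an assay on microsomes from intestine for inhibition of acyl-CoA:cholesterol acyltransferase (Oryctolagus cuniculus); on this read-out higher numbers stand for weaker inhibition and lower numbers for stronger inhibition:
- compound 1, `CC(C)c1cccc(C(C)C)c1OC(=O)NC(=O)N(c1ccccc1)c1ccccc1`; compound 1 gives 170 nM
- compound 2, `CC(C)(C)c1cccc(C(C)(C)C)c1OC(=O)NC(=O)Oc1c(C(C)(C)C)cccc1C(C)(C)C`; compound 2 gives 1200 nM
- compound 3, `CCCCCCOC(=O)NC(=O)Oc1c(C(C)C)cccc1C(C)C`; compound 3 gives 53 nM

Of these three numbers compound 3 holds the lowest. Compound 1 stands nearest to it, yet the gap between the two lies beyond the scatter; compound 2 stands furthest, again beyond the scatter. Within the data shown here, no pair among the measured compounds differs in a single place, so no measured step is at hand.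

Compound 4, `CCCCCCCCCCCCCCCCOC(=O)NC(=O)Oc1c(C(C)C)cccc1C(C)C`, differs from compound 3 by decyl in place of hydrogen on a saturated chain carbon, six bonds along the chain from an oxygen next to a carbonyl group. Among the measured compounds shown here, nothing among the measured compounds tracks a change of this kind, so the expectation rests on compound 3 alone. The step of a 1.1-fold higher number from compound 3 to compound 4 (0.05 log units; within the scatter) is expected to stay within the scatter, with no clear direction. Compound 4 is therefore estimated at 60 nM, in the range from 20 nM to 200 nM.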

Compound 4, half-maximal inhibitory concentration: 50 nM
Compound 4: middle estimate off by 1.2-fold (0.08 log units), on the high side; the range from low to high includes it.
By their numbers in this assay, from the lowest: compounds 4 and 3 (each within the scatter of the next); then compound 1; then compound 2.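

Decyl in place of hydrogen on a saturated chain carbon, six bonds along the chain from an oxygen next to a carbonyl group, gives a 1.1-fold lower number from compound 3 to compound 4 (0.03 log units; within the scatter) in this assay. Among these compounds, at this place, then, the chain can grow by these 10 carbon atoms with no shift beyond the scatter, something the earlier compounds, which offered no single-place step, could not show. Nothing shown explains this flat result.

On these data alone, whether a carboxylic acid or an amine at the end of the chain would leave the number as flat stays open. So does the effect of a still longer chain or a phenyl ring there.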